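Allyl ether to free hydroxy: a working note

This account rests on a few compounds, and the source may have more. Where it says the series, first, only, none or still open, it means among the compounds named here.

Measured in a functional assay on IMR-32 cells (Homo sapiens) for cytotoxicity, read by sulforhodamine B assay, with a stated time of 48 h; a higher number here means a weaker inhibitor, a lower number a stronger inhibitor:
compound 1 `C=CCOc1ccc(F)cc1C(=O)c1cccnc1`: 91000 nM
compound 2 `C=CCOc1ccc(Br)cc1C(=O)c1cccnc1`: 88000 nM
compound 3 `C=CCOc1c(Cl)cc(Cl)cc1C(=O)c1cccnc1`: 52000 nM

Compound 2 stands second highest of the three numbers. Its nearest neighbour is compound 1, whose value sits within the scatter of it; the furthest is compound 3, whose lower number is also within the scatter, so the three cannot be ordered.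

Compound 4 `O=C(c1cccnc1)c1cc(Br)ccc1O` differs from compound 2 by hydrogen in place of allyl on an oxygen on an aromatic ring. Among the measured compounds shown here, the only single-point step measured, a 1.0-fold lower number from compound 1 to compound 2 (0.01 log units; within the scatter), concerns a halogen on the aromatic carbon and says nothing about the oxygen. For the measured compounds named here, no measured step bears on the removal of the allyl group, so the expectation rests on the flat landscape of compounds 1, 2 and 3 alone.

On that basis compound 4 is expected to show no step beyond the scatter, a 1.0-fold higher number from compound 2 to compound 4 (0.01 log units; within the scatter), with an estimate of 90000 nM and a range from 40000 nM to 200000 nM.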

Compound 4, half-maximal inhibitory concentration: 23400 nM
For compound 4 the middle estimate is 3.8-fold (0.59 log units) above the measured one; measured number below the stated range.
By their numbers in this assay, from the lowest: compound 4; then compounds 3, 2 and 1 (each within the scatter of the next).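

Swapping allyloxy for hydroxy gives the only step shown beyond the scatter in this assay, a 3.8-fold lower number from compound 2 to compound 4 (0.58 log units; beyond the scatter), so the substituent on this oxygen moves the number, whereas the halogen change between compound 1 and compound 2 did not. The step is modest and rests on a single pair. Nothing available accounts for it.

Going by these compounds, it remains open whether the free hydroxy or simply the loss of allyl matters, and whether the change carries over to compound 1 or compound 3. A methoxy group or a longer chain such as butoxy on this oxygen would help separate these readings.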